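The source may hold more compounds than are shown below. What is called first, only, known or untested is meant among the compounds shown, and "the series" means these compounds.

Of the compounds shown here, two with a shared core have been tested. Compound 1 `Brc1ccccc1OCC1=NCCO1` gives 20.1% in a functional assay on the whole organism for inhibition, with Rattus norvegicus as the target, read by paw edema, with a stated time of 30 min, at a dose of 20 mg/kg by the oral route; a lower number here means a weaker effect, a higher number a stronger effect of the compound at the dose given. Compound 2 `O=[N+]([O-])c1ccccc1OCC1=NCCO1` gives 20.5% in this assay. The step from one to the other is a number 0.4 percentage points higher from compound 1 to compound 2 (within the scatter), so compound 2 stands alongside compound 1, the two numbers lying within the scatter of one another.

Compound 3 `Fc1ccccc1OCC1=NCCO1` has not yet been measured. Its change from compound 2 is fluoro in place of nitro on an aromatic carbon. Among the measured compounds shown here, the only step measured so far, a number 0.4 percentage points higher from compound 1 to compound 2 (within the scatter), swapped one substituent for another at this same place and moved the read-out by an amount within the scatter; no step involving fluoro at this position exists. On that basis the expected step is a number 2.5 percentage points lower from compound 2 to compound 3 (within the scatter), that is, none beyond the scatter in either direction. Compound 3 is therefore estimated at 18%, with a range from 6% to 30%.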

Compound 3, a percentage reported as inhibition, in the whole organism at one dose (the size of the read-out at that dose, not a potency): 20.6%
Estimate against measurement, compound 3: 2.6 percentage points below, and the stated range covers the measured number.
By their numbers in this assay, from the lowest: compounds 1, 2 and 3 (each within the scatter of the next).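

With fluoro in place of nitro, a single heavy atom replaces a group of three, yet this assay shows a number 0.1 percentage points higher from compound 2 to compound 3 (within the scatter). Fluoro in place of bromo gives the same picture, with a number 0.5 percentage points higher from compound 1 to compound 3 (within the scatter). Across these three compounds, then, the choice among bromo, nitro and fluoro at this place on the aromatic ring leaves the read-out within the scatter, and nothing available here bears on why the three read alike.

Still open, going by these compounds, is whether an amine, a carboxylic acid or a longer chain such as an ethoxy group at this same place would move the read-out beyond the scatter, and whether plain hydrogen there would differ from these three. On these data alone, all three numbers also come from a single dose, so how the compounds compare at other doses remains unknown.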